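The source may report more compounds than this note shows. Statements on the series, on what has been measured and on what is new or still open speak of the compounds shown alone.

Measured so far:
Compound 1 `Nc1scc(CN2CCN(c3ccc(OC(F)(F)F)cc3)CC2)c1C(=O)c1ccc(Cl)cc1`: -74%
Compound 2 `Nc1scc(CN2CCN(c3ccncc3)CC2)c1C(=O)c1ccc(Cl)cc1`: -15%
Compound 3 `Nc1scc(CN2CCN(c3cc(F)cc(F)c3)CC2)c1C(=O)c1ccc(Cl)cc1`: -79%

In a functional assay on CHO cells with adenosine receptor A1 (Homo sapiens) as the target, read by cAMP accumulation and immunoassay, with a stated time of 6 min, tested at 10 uM (on this read-out lower numbers stand for a stronger effect and higher numbers for a weaker effect at the one concentration tested), compound 3 gives the lowest of the three numbers. Its distance from compound 1 is small, a number 5 percentage points lower from compound 1 to compound 3 (within the scatter), while its distance from compound 2 is large, a number 64 percentage points lower from compound 2 to compound 3 (beyond the scatter). Compound 4 `Nc1scc(CN2CCN(c3ccccc3Cl)CC2)c1C(=O)c1ccc(Cl)cc1` has not been measured. Its structural difference from compound 3 is 2-chlorophenyl in place of 3,5-difluorophenyl on an amine nitrogen in a ring. Both measured steps swap the group on the same ring nitrogen: exchanging one six-membered aromatic ring of carbon only for another changed little, whereas exchanging a pyridin-4-yl for such a ring changed much. The entering 2-chlorophenyl is again a six-membered aromatic ring of carbon only, so only a small step, a number 9 percentage points higher from compound 3 to compound 4 (within the scatter), is expected. Compound 4 is estimated at -70%, within -90% to -40%.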

Compound 4, a percentage reported as activity, at one concentration (the size of the read-out at that concentration, not a potency): -18%
Compound 4: middle estimate off by 52 percentage points, on the low side; the measured number lies above the stated range.
By their numbers in this assay, from the lowest: compounds 3 and 1 (each within the scatter of the next); then compounds 4 and 2 (each within the scatter of the next).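

On the amine nitrogen in the ring, keeping a six-membered aromatic ring of carbon only does not keep the effect in this assay (a number 61 percentage points higher from compound 3 to compound 4 (beyond the scatter); a number 56 percentage points higher from compound 1 to compound 4 (beyond the scatter)). The 2-chlorophenyl and pyridin-4-yl groups cannot be told apart here (a number 3 percentage points lower from compound 2 to compound 4 (within the scatter)), so the ring type alone does not set the read-out. Nothing available explains this difference. As far as these compounds go, it remains open whether the chlorine itself or its place on the ring matters, and how a phenyl ring carrying a methyl group, a methoxy group or a nitrile would read.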